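A few compounds are considered here, and "the series" means these few. Any claim that something is new, unique, unknown or untested is made for them only; others in the source may bear on it.

In a functional assay on HepG2 cells (Homo sapiens) for antiproliferative activity, read by CCK-8 assay, with a stated time of 72 h (a lower number here means a stronger inhibitor, a higher number a weaker inhibitor), compound 1 `O=C(/C=C/c1ccc(CN2CCc3ccccc32)cc1)NO` gives 14900 nM. Compound 2 `Nc1ccccc1NC(=O)/C=C/c1ccc(COc2ccccc2)cc1` has only a limit, > 32000 nM. Compound 3 `Nc1ccccc1NC(=O)/C=C/c1ccc(CN2CCc3ccccc32)cc1` differs from compound 2 by one change: 2,3-dihydro-1H-indol-1-yl in place of phenoxy on a saturated chain carbon bound to an aromatic carbon. Going by the values given here, no measured step covers this change. Among the compounds with values here, the only guide is compound 1, which carries the same entering group and gives 14900 nM. In this assay a small step towards a stronger inhibitor is expected, an at least 1.2-fold lower number from compound 2 to compound 3 (0.10 log units; that floor lies within the scatter). The estimate for compound 3 is 25000 nM, with an expected range of 10000 nM to 60000 nM.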

Compound 3, half-maximal inhibitory concentration: > 32000 nM
Compound 3: only a limit was reported; the forecaster's own chance of this, stated with the estimate: 50%; middle value at least 1.2-fold (0.10 log units) from the limit.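

With 2,3-dihydro-1H-indol-1-yl held constant, 2-aminophenyl in place of hydroxy on an amide-type nitrogen gives an at least 2.1-fold higher number from compound 1 to compound 3 (0.33 log units; beyond the scatter) in this assay. This change therefore moves the compound out of the readable range, leaving compound 1 as the only compound shown with a numerical value. The values of compound 2 and compound 3 are both limits, so the step between them cannot be read: the limit of > 32000 nM in this assay, at which 2 of the 3 values shown sit.

Still open, going by these compounds, is whether piperidin-1-yl on the saturated chain carbon would bring a 2-aminophenyl compound to a readable value. Also open, on these data alone, is how phenoxy behaves with hydroxy on the amide-type nitrogen.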